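Cytotoxicity notes on the coumarin–indole propionate series

The compounds below may be only part of what the source reports. "The series", "measured", "known", "first", "only" and "open" are said of these compounds alone.

Measured compounds in an ADME assay on MT4 cells (Homo sapiens) for cytotoxicity, read by MTT assay, with a stated time of 96 h; a higher number here means that more compound is tolerated, a lower number that less compound is tolerated:
- compound 1 `CCC(=O)Oc1ccc2ccc(=O)oc2c1Cc1c(-c2ccccc2)[nH]c2ccccc12`: compound 1 gives > 100000 nM
- compound 2 `CCC(=O)Oc1ccc2c(C)cc(=O)oc2c1Cc1c(-c2ccccc2)[nH]c2ccccc12`: compound 2 gives 38000 nM
- compound 3 `CC(=O)Oc1ccc2ccc(=O)oc2c1Cc1c(-c2ccccc2)[nH]c2ccccc12`: compound 3 gives > 100000 nM

Compound 1 sits at the assay limit of the limit of > 100000 nM in this assay, at which 2 of the 3 values shown sit; its value is a limit, not a number. Compound 3 likewise returns only a limit in this assay. Going by the values given here, compound 2 alone gives a read number, and the step of an at least 2.6-fold lower number from compound 1 to compound 2 (0.42 log units; beyond the scatter), methyl in place of hydrogen on an aromatic carbon, is the one readable change. The step that the two limits leave unreadable from compound 1 to compound 3 cannot be sized, since both ends are limits.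

Compound 4 `CCC(=O)Oc1ccc2ccc(=O)oc2c1Cc1c[nH]c2ccccc12` differs from compound 1 by hydrogen in place of phenyl on an aromatic carbon. Among the compounds with values here, no measured step touches the phenyl on the five-membered ring, so neither measured step bears directly on this change. Since two of the three values sit at the limit (the limit of > 100000 nM in this assay, at which 2 of the 3 values shown sit), compound 4 is expected to remain near the limit as well, with a step of a number no higher from compound 1 to compound 4 (the limit leaves the size open) that is not expected to exceed the scatter. Compound 4 is estimated at 100000 nM, in the range 40000 nM to 250000 nM.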

Compound 4, half-maximal cytotoxic concentration: 65000 nM
Estimate against measurement, compound 4: 1.5-fold (0.19 log units) above; the measured number falls inside the stated range.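

In this assay, the place on the five-membered aromatic ring next to the ring nitrogen now has its first direct reading: hydrogen in place of phenyl gives an at least 1.5-fold lower number from compound 1 to compound 4 (0.18 log units; that floor lies within the scatter). The change turns a limit into a read number, yet only a floor can be given for the step, so a true difference within the scatter is not excluded. The other end of this step is only a limit, and it is not a number: the limit of > 100000 nM in this assay, at which 2 of the 4 values shown sit.

Still open, as far as these compounds go, is how a methyl, a longer chain, an amine or a carboxylic acid at this place would read against hydrogen and phenyl. Going by these compounds alone, also open is whether methyl in place of hydrogen on the aromatic carbon, the change that gave the one clear step so far, would have the same outcome without the phenyl.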